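Compound 4: A Fluoro-Methoxy Aryl on the Ring Nitrogen

A few compounds are considered here, and "the series" means these few. Any claim that something is new, unique, unknown or untested is made for them only; others in the source may bear on it.

Compound 1 `O=C(NCCCCc1ccccc1)c1cccc(C2SCC(=O)N2c2ccccc2)c1` has the lowest number of the three measured compounds in a functional assay on HOS cells (Homo sapiens) for inhibition, read by CCK-8 assay, with a stated time of 72 h, tested at 1 uM; on this read-out higher numbers stand for more inhibition at the one concentration tested (going by the name of the read-out) and lower numbers for less inhibition: compound 1 gives 55%, the lowest of the three numbers. Compound 2 `COc1cccc(OC)c1N1C(=O)CSC1c1cccc(C(=O)NCCCCc2ccccc2)c1` gives 80% and compound 3 `O=C(NCCCCc1ccccc1)c1cccc(C2SCC(=O)N2c2ccccc2F)c1` gives 83%. Compound 4 `COc1c(F)cccc1N1C(=O)CSC1c1cccc(C(=O)NCCCCc2ccccc2)c1` differs from compound 1 by 3-fluoro-2-methoxyphenyl in place of phenyl on an amide-type nitrogen in a ring. Going by the values given here, two measured steps bear on this change: a number 25 percentage points higher from compound 1 to compound 2 (beyond the scatter), and a number 28 percentage points higher from compound 1 to compound 3 (beyond the scatter). Between the two substituted aryl compounds the gap is small: a number 3 percentage points higher from compound 2 to compound 3 (within the scatter). Both a methoxy-bearing and a fluoro-bearing aryl raised the number, so a similar modest rise is expected for compound 4, a number 25 percentage points higher from compound 1 to compound 4 (beyond the scatter). Compound 4 is therefore estimated at 80%, with a range from 65% to 92%.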

Compound 4, a percentage reported as inhibition, at one concentration (the size of the read-out at that concentration, not a potency): 9%
The estimate for compound 4 lay 71 percentage points above the measured number, and the stated range ends above it.
By their numbers in this assay, from the lowest: compound 4; then compound 1; then compounds 2 and 3 (each within the scatter of the next).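

In this assay, going by these compounds alone, the aryl on the amide-type nitrogen proved far less forgiving than the earlier compounds suggested: with a number 46 percentage points lower from compound 1 to compound 4 (beyond the scatter) as the step, substitution on this ring does not by itself raise the number. With a number 74 percentage points lower from compound 3 to compound 4 (beyond the scatter) and a number 71 percentage points lower from compound 2 to compound 4 (beyond the scatter) as the further steps, a fluoro and a methoxy together on this ring do not reproduce what 2-fluorophenyl or 2,6-dimethoxyphenyl gave. No measurement at hand accounts for this drop.

The compounds shown leave open whether a lone 2-methoxyphenyl or 3-fluorophenyl would keep the number of compound 3 or fall towards that of compound 4. They also leave open how an aryl carrying an amine or a carboxylic acid would behave here.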